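Extending the Chain of Compound 1 by Two Carbons

The compounds below may be only part of what the source reports. "The series", "measured", "known", "first", "only" and "open" are said of these compounds alone.

Compound 1, `CC[C@@H](CCn1cncn1)c1ccccc1`, is tested in an ADME assay on HEp-2 cells (Homo sapiens) for cytotoxicity, read by MTT assay, with a stated time of 3 days (a lower number here means that less compound is tolerated, a higher number that more compound is tolerated), where compound 1 gives 89.9 ug/mL. Two ring-substituted relatives frame it. Compound 2, `CC[C@@H](CCn1cncn1)c1ccc(Cl)cc1`, gives 55.1 ug/mL, and compound 3, `CC[C@@H](CCn1cncn1)c1ccc(OC)cc1`, gives 146 ug/mL. The number for compound 1 lies between those of compound 2 and compound 3, and neither step reaches beyond the scatter: a 1.6-fold lower number from compound 1 to compound 2 (0.21 log units; within the scatter), while a 1.6-fold higher number from compound 1 to compound 3 (0.21 log units; within the scatter). Only the direct comparison of the two relatives is larger, since a 2.6-fold higher number from compound 2 to compound 3 (0.42 log units; beyond the scatter).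

Compound 4, `CCCC[C@@H](CCn1cncn1)c1ccccc1`, differs from compound 1 by ethyl in place of hydrogen on a saturated chain carbon, three bonds along the chain from an aromatic carbon. Every measured step here alters a group on the aromatic ring; none touches the saturated chain. The measured steps therefore offer no direct guide, and the three numbers gathered so far span only a modest range. On that basis no step beyond the scatter is expected in this assay, so that a 1.0-fold higher number from compound 1 to compound 4 (0.00 log units; within the scatter) is the expected outcome. Compound 4 is estimated at 90 ug/mL, within a range from 45 ug/mL to 180 ug/mL.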

Compound 4, half-maximal cytotoxic concentration: 40.8 ug/mL
Compound 4: middle estimate off by 2.2-fold (0.34 log units), on the high side, outside the stated range (below it).
By their numbers in this assay, from the lowest: compounds 4, 2, 1 and 3 (each within the scatter of the next, the first and the last beyond it).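

Ethyl in place of hydrogen on this saturated chain carbon gives a 2.2-fold lower number from compound 1 to compound 4 (0.34 log units; beyond the scatter) in this assay and so shows that the chain position, which the earlier compounds left untouched, can shift how much compound the cells tolerate. Going by these compounds alone, neither ring change starting from compound 1 moved the number beyond the scatter, so this is the first single change from compound 1 that does. Nothing available here accounts for this shift.

With only hydrogen and ethyl compared at this position, a single step cannot show a trend with chain length. From the compounds shown here alone, whether methyl, a longer chain such as hexyl, or an amine on the chain would lower the number further, and whether the chloro or methoxy ring groups would act the same way alongside ethyl, stays open.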